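Working notes: oxan-4-yl in place of oxolan-2-yl

The source may report more compounds than this note shows. Statements on the series, on what has been measured and on what is new or still open speak of the compounds shown alone.

- compound 1 `Cc1cc(C(=O)NCc2cccnc2)nn1Cc1cc(Cl)ccc1OCc1ccccc1` in a physicochemical assay for lipophilicity, at pH 7.4; a higher number here means a more lipophilic compound, a lower number a more polar compound: > 3.7 (a limit)
- compound 2 `CC(=O)Nc1cc(C)n(Cc2cc(Cl)ccc2OCc2ccccc2)n1` in this assay: > 3.7 (a limit)
- compound 3 `Cc1cc(NC(=O)C2CCCO2)nn1Cc1cc(Cl)ccc1OCc1ccccc1` in this assay: > 3.7 (a limit)

Compound 3 stands at > 3.7 in this assay, which is a limit of the assay and not a number. The only reference point in the series is the limit of > 3.7 in this assay, at which 3 of the 3 values shown sit.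

Compound 4 `Cc1cc(NC(=O)C2CCOCC2)nn1Cc1cc(Cl)ccc1OCc1ccccc1` carries oxan-4-yl in place of oxolan-2-yl on a carbonyl carbon. A five-membered non-aromatic ring thus gives way to a six-membered one, at a carbonyl carbon whose other neighbour is an amide-type nitrogen.

The closest measured change is a step that the two limits leave unreadable from compound 2 to compound 3, made on the same kind of carbonyl carbon. The other two are a step that the two limits leave unreadable from compound 1 to compound 2 and a step that the two limits leave unreadable from compound 1 to compound 3, both of which replace ((pyridin-3-yl)methyl)carbamoyl on an aromatic carbon and bear less directly. None of the three has a readable size, so they give no direction and no magnitude.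

No shift beyond the scatter is therefore expected in this assay. The expected change is a step that the limit leaves unreadable from compound 3 to compound 4. This expectation rests on compound 3 at > 3.7, itself a limit. Another limit reading is the likely outcome. Compound 4 is estimated at 4.1, with an expected range from 3.7 to 4.6.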

Compound 4, distribution coefficient: > 3.7
Compound 4 gave a limit, no number (the forecaster's own chance of this, stated with the estimate: 80%); the middle value lies beyond the limit too.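

No new step can be read between compound 4 and compound 1, compound 2 or compound 3, because each of these compounds gives only a limit of the assay and not a number, with every pair at the same reading: the limit of > 3.7 in this assay, at which 4 of the 4 values shown sit.

The compounds shown leave open how far apart any of them lie in this assay, including whether oxan-4-yl in place of oxolan-2-yl changes the value at all.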